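The source may report more compounds than this note shows. Statements on the series, on what has been measured and on what is new or still open speak of the compounds shown alone.

Working notes on the series in a toxicity assay on the whole organism (strain Icem-CET (SPF Caw)) for cytotoxicity, with Mus musculus as the target; a higher number here means that more compound is needed for the effect, a lower number that less compound is needed. Three amides on a shared core have numbers. Compound 1 `C/C(C(=O)NC1CC1)=C(/C)c1ccc(Br)cc1` gives 100 mg/kg. Compound 2 `C#CCNC(=O)/C(C)=C(\C)c1ccc(Cl)cc1` gives 60 mg/kg. Compound 3 `C/C(C(=O)NC1CC1)=C(\C)c1ccc(Cl)cc1` gives 170 mg/kg, the highest of the three numbers; the gap to compound 1 stays within the scatter, the gap to compound 2 lies beyond it. Among the three measured compounds no pair differs in one place only, so no step can be read off directly.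

Compound 4 `C/C(C(=O)NC1CC1)=C(/C)c1ccc(Cl)cc1` is the next point. Relative to compound 3 the change is: the two compounds have the same atoms and bonds and differ only in configuration as drawn: 1 of 1 stereo elements differ; a double bond is drawn Z in compound 3 and E in compound 4. Nothing measured here isolates this kind of change on its own. What can be noted is that compound 1 is drawn in the same configuration as compound 4 and carries a bromo group where compound 4 carries a chloro group, and the reading of compound 1 at 100 mg/kg and that of compound 3 at 170 mg/kg sit within the scatter of each other.

On that basis the step is expected to fall within the scatter, in no settled direction, with the expected step being a 1.3-fold lower number from compound 3 to compound 4 (0.12 log units; within the scatter). For compound 4 the estimate in this assay is 130 mg/kg, expected to fall between 60 mg/kg and 260 mg/kg.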

Compound 4, dose for half-maximal effect: 350 mg/kg
Compound 4: the middle estimate sits 2.7-fold (0.43 log units) below what was measured; the measured number lies above the stated range.
By their numbers in this assay, from the lowest: compounds 2, 1 and 3 (each within the scatter of the next, the first and the last beyond it); then compound 4.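

In this assay, within the data shown here, the configuration of the double bond alone now has a readable effect, which no earlier pair could show: a 2.1-fold higher number from compound 3 to compound 4 (0.31 log units; beyond the scatter). That step, beyond the scatter, can be assigned to the double bond and not to any other part of the structure because of one point: the fact that compounds 3 and 4 differ only in the configuration as drawn. Compound 4 also gives the series its first single-place readings at the other two sites, both beyond the scatter and both in the same direction: with cyclopropyl in place of propargyl on the amide-type nitrogen there is a 5.8-fold higher number from compound 2 to compound 4 (0.77 log units; beyond the scatter), and with chloro in place of bromo on the aromatic carbon there is a 3.5-fold higher number from compound 1 to compound 4 (0.54 log units; beyond the scatter).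

The compounds shown leave open whether the configuration step keeps its direction and size with bromo on the aromatic carbon or with propargyl on the amide-type nitrogen. They also leave open how a longer chain, an amine or a carboxylic acid on that nitrogen would read against cyclopropyl, and how fluoro or methoxy would read against chloro.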